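A chlorine removed from the aryl group of compound 2

A few compounds are considered here, and "the series" means these few. Any claim that something is new, unique, unknown or untested is made for them only; others in the source may bear on it.

Two compounds of this set carry a measured value. Compound 1 `COc1cc2c(cc1OC)C(c1ccc(N)cc1)=NN=C(S)C2` and compound 2 `COc1cc2c(cc1OC)C(c1ccc(Cl)cc1)=NNC(=O)C2` share a core and differ in the substituent on the pendant aromatic ring and in the lactam part. In a functional assay on the whole organism with Mus musculus as the target (on this read-out lower numbers stand for an effect already at smaller amounts and higher numbers for an effect only at larger amounts of compound), compound 1 gives 6.3 umol/kg, while compound 2 gives 102 umol/kg. Compound 2 thus stands at the highest number of the two, its nearest neighbour being compound 1, whose number is far lower, beyond the usual scatter. Among the measured compounds shown here, because the two compounds differ in more than one place, no single step connects them, and the gap is only what the two values show.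

Compound 3 `COc1cc2c(cc1OC)C(c1ccccc1)=NNC(=O)C2` is not yet measured. Its change from compound 2 is hydrogen in place of chloro on an aromatic carbon. For the measured compounds named here, with no step between measured compounds to lean on, the size of this step is open; a modest rise in the number, or none beyond the scatter, is expected. The estimated step is a 1.5-fold higher number from compound 2 to compound 3 (0.17 log units; within the scatter). Compound 3 is therefore expected to give about 150 umol/kg, with a range from 50 umol/kg to 450 umol/kg.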

Compound 3, dose for half-maximal effect: 33.9 umol/kg
The estimate for compound 3 lay 4.4-fold (0.65 log units) above the measured number, outside the stated range (below it).
By their numbers in this assay, from the lowest: compound 1; then compound 3; then compound 2.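

Among the compounds shown here, this is the first step in the set that changes one place only: in this assay, hydrogen in place of chloro on the aromatic carbon gives a 3.0-fold lower number from compound 2 to compound 3 (0.48 log units; beyond the scatter) with the rest of the structure unchanged. It shows that, on this scaffold, the chloro para to a large group is not needed for the effect, and that the change from 4-chlorophenyl to phenyl moves the number by more than the usual scatter, towards an effect at smaller amounts of compound. Nothing at hand bears on why this change lowers the number.

Going by these compounds, the step covers only chloro and hydrogen, so whether a fluoro, a methyl or a carboxylic acid on the same aromatic carbon would give a lower or a higher number than compound 3 stays open, as does whether the step would hold on another core. The amino group of compound 1 cannot be judged against this step, since compound 1 differs from compound 3 in more than one place, and what the amino group and the other difference each contribute remains unresolved.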